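Series of chlorinated purine glycinamide esters in the tail flick test

A few compounds are considered here, and "the series" means these few. Any claim that something is new, unique, unknown or untested is made for them only; others in the source may bear on it.

For the measured compounds named here, compound 3 `N=C(N)NCCC[C@H](NC(=O)CN(c1nc(Cl)nc2[nH]cnc12)C1CC1)C(=O)OCc1ccccc1` gives 10.2% in a functional assay on the whole organism (Tail, strain ICR) with Mus musculus as the target, in the tail flick test, with a stated time of 120 min, at a dose of 25 umol/kg by the oral route (on this read-out lower numbers stand for a weaker effect and higher numbers for a stronger effect at the one dose given), the lowest of the three numbers known. Compound 1 `O=C(CN(c1nc(Cl)nc2[nH]cnc12)C1CC1)N[C@@H](CO)C(=O)OCc1ccccc1` gives 34.5% and compound 2 `O=C(CN(c1nc(Cl)nc2[nH]cnc12)C1CC1)NCC(=O)OCc1ccccc1` gives 21.7% in this assay. Compound 4 `O=C(CN(c1nc(Cl)nc2[nH]cnc12)C1CC1)N[C@@H](CC(=O)OCc1ccccc1)C(=O)OCc1ccccc1` differs from compound 3 by a group of 10 heavy atoms (8 carbon, 2 oxygen; one six-membered aromatic ring of carbon only) in place of a group of 6 heavy atoms (3 carbon, 3 nitrogen; no ring), on a saturated chain carbon, two bonds along the chain from an amide-type nitrogen and a carbonyl carbon. Going by the values given here, the steps that bear on this are a number 24.3 percentage points lower from compound 1 to compound 3 (beyond the scatter) and a number 11.5 percentage points lower from compound 2 to compound 3 (beyond the scatter), both attached to the entry of the group that now leaves. Among the compounds with values here, its removal is expected to return part of that loss, though no measured step shows what the entering group does at this place. Compound 4 is therefore expected to give 22%, between 10% and 36%, a step of a number 11.8 percentage points higher from compound 3 to compound 4 (beyond the scatter).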

Compound 4, a percentage reported as activity, at one dose (the size of the read-out at that dose, not a potency): 12.1%
Beside the measured number, compound 4's estimate is 9.9 percentage points above it; measured number inside the range.
By their numbers in this assay, from the lowest: compounds 3, 4 and 2 (each within the scatter of the next, the first and the last beyond it); then compound 1.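

Benzyloxycarbonyl in place of the group of 6 heavy atoms gives a number 1.9 percentage points higher from compound 3 to compound 4 (within the scatter) in this assay, so this position tolerates two very different entering groups with no readable difference. (Benzyloxycarbonyl)methyl in place of hydrogen gives a number 9.6 percentage points lower from compound 2 to compound 4 (within the scatter) and so also brings no readable change, while benzyloxycarbonyl in place of hydroxy gives a number 22.4 percentage points lower from compound 1 to compound 4 (beyond the scatter) as a clear loss. Among the four compounds, only the hydroxymethyl of compound 1 stands apart from the rest. As far as these compounds go, whether a carboxylic acid, an amine or a longer hydroxyalkyl chain at this carbon would match hydroxymethyl remains open. No evidence is available to explain these results.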